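Dichlorophenyl Amide with a Piperazine Ring in Place of a Chain

A few compounds are considered here, and "the series" means these few. Any claim that something is new, unique, unknown or untested is made for them only; others in the source may bear on it.

Compound 2 `Cc1cc(NCCN(C)C)nc2ccc(NC(=O)c3ccc(Cl)c(Cl)c3)cc12` gives the lowest number of the three measured compounds in a functional assay on SK-BR-3 cells (Homo sapiens) for antiproliferative activity, read by MTT assay, with a stated time of 72 h (on this read-out higher numbers stand for weaker inhibition and lower numbers for stronger inhibition), at 6670 nM. Compound 3 `CCc1ccc(C(=O)Nc2ccc3nc(N4CCN(CC)CC4)cc(C)c3c2)cc1` gives 9850 nM, a value within the scatter of compound 2, so no order between the two can be claimed. Compound 1 `CCN1CCN(c2cc(C)c3cc(NC(=O)c4ccccc4F)ccc3n2)CC1` gives 38100 nM, which stands beyond the scatter from compound 2. Compound 4 `CCN1CCN(c2cc(C)c3cc(NC(=O)c4ccc(Cl)c(Cl)c4)ccc3n2)CC1` has not yet been measured; it differs from compound 2 in 4-ethylpiperazin-1-yl in place of (2-(dimethylamino)ethyl)amino on an aromatic carbon. For the measured compounds named here, the single measured step, a 3.9-fold lower number from compound 1 to compound 3 (0.59 log units; beyond the scatter), concerns the group on the carbonyl carbon and leaves the amine side untouched, so no measured step bears directly on this change. Compounds 1 and 3 both carry the 4-ethylpiperazin-1-yl group and both give higher numbers than compound 2, though compound 3 lies within the scatter of it. For compound 4 a small step is therefore expected, a 1.2-fold higher number from compound 2 to compound 4 (0.08 log units; within the scatter), with the direction uncertain. Compound 4 is estimated at 8000 nM, with a range from 2500 nM to 25000 nM.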

Compound 4, half-maximal inhibitory concentration in the SK-BR-3 assay: 2160 nM
Beside the measured number, compound 4's estimate is 3.7-fold (0.57 log units) above it; measured number below the stated range.
By their numbers in the SK-BR-3 assay, from the lowest: compound 4; then compounds 2 and 3 (each within the scatter of the next); then compound 1.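

At the aromatic carbon next to the ring nitrogen, the ring of 4-ethylpiperazin-1-yl proves better than the open (2-(dimethylamino)ethyl)amino chain in the SK-BR-3 assay, with a 3.1-fold lower number from compound 2 to compound 4 (0.49 log units; beyond the scatter), so the amine side matters on its own. With that ring held fixed in the SK-BR-3 assay, 3,4-dichlorophenyl on the carbonyl carbon outdoes both other aryl groups, with a 4.6-fold lower number from compound 3 to compound 4 (0.66 log units; beyond the scatter) and an 18-fold lower number from compound 1 to compound 4 (1.25 log units; beyond the scatter). In a physicochemical assay for lipophilicity, at pH 7.4 (on this read-out lower numbers stand for lower lipophilicity and higher numbers for higher lipophilicity), compound 2 gives 1.47 and compound 4 gives 3.67, so the same change also moves the distribution coefficient upward.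

The compounds shown cannot separate these two shifts, so it stays open whether the gain follows the distribution coefficient or the ring itself. A morpholine or an unsubstituted piperazine at this position would test how much depends on the second ring nitrogen and its ethyl group.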